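A few compounds are considered here, and "the series" means these few. Any claim that something is new, unique, unknown or untested is made for them only; others in the source may bear on it.

Measured in a functional assay on HeLa cells (Homo sapiens) for inhibition, read by MTT assay, with a stated time of 48 h; on this read-out lower numbers stand for stronger inhibition and higher numbers for weaker inhibition:
compound 1 `COc1ccc2c(=O)c(/C=C/C(=O)NCc3ccccc3)coc2c1` — 33400 nM
compound 2 `COc1ccc2c(=O)c(/C=C/C(=O)NCc3ccccc3F)coc2c1` — > 100000 nM; this is a limit of the assay, not a number.

Compound 2 therefore stands at the bound (the limit of > 100000 nM in this assay, at which 1 of the 2 values shown sits), the weaker end of the two measured compounds, with no exact value. For the measured compounds named here, the only measured step in this assay is an at least 2.9-fold higher number from compound 1 to compound 2 (0.47 log units; beyond the scatter), beyond the scatter. Compound 3 `COc1ccc2c(=O)c(/C=C/C(=O)Nc3ccccc3C)coc2c1` differs from compound 2 by 2-methylphenyl in place of 2-fluorobenzyl on an amide-type nitrogen. Going by the values given here, no measured step covers the move from a benzyl-type amide to an aryl amide, nor the swap of fluoro for methyl, so the measured step bears on this change only loosely. With compound 2 known only as a limit, the step that the limit leaves unreadable from compound 2 to compound 3 is expected to be none beyond the scatter. Compound 3 is thus expected to sit near the same bound, estimated at 120000 nM, between 40000 nM and 400000 nM.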

Compound 3, half-maximal inhibitory concentration: 7270 nM
Compound 3: middle estimate off by 17-fold (1.22 log units), on the high side, and the stated range ends above it.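

In this assay, 2-methylphenyl in place of benzyl on an amide-type nitrogen gives a 4.6-fold lower number from compound 1 to compound 3 (0.66 log units; beyond the scatter), so this position can move to a lower number as well as the higher one seen with fluoro. Against 2-fluorobenzyl, the same entering group gives an at least 13-fold lower number from compound 2 to compound 3 (1.13 log units; beyond the scatter). That step has an open-ended size because compound 2 carries a limit and not a number: the limit of > 100000 nM in this assay, at which 1 of the 3 values shown sits.

From the compounds shown here alone, both steps change the link to the ring and the ring substituent together, so the share of each remains open; a plain phenyl or a 2-methylbenzyl group on the same nitrogen would separate them. Going by these compounds, how an amine or a carboxylic acid on that ring would read in this assay also remains open.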